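Replacing methoxycarbonyl with cyano in compound 3

The source may hold more compounds than are shown below. What is called first, only, known or untested is meant among the compounds shown, and "the series" means these compounds.

Measured so far in a functional assay on a cell-free system (plasma, Oryctolagus cuniculus) for inhibition, with stated times of 5 min, 1 min and 6 min; on this read-out higher numbers stand for weaker inhibition and lower numbers for stronger inhibition:
Compound 1 `CCOC(=O)c1c(C)nc(-c2cccc(C#N)c2)n1O` gives 17600 nM
Compound 2 `CCOC(=O)c1c(C)nc(-c2cccc(C#N)c2)n1OCCC(=O)O` gives > 30000 nM (a limit, not a number)
Compound 3 `CCOC(=O)c1c(C)nc(-c2cccc(C#N)c2)n1OCc1ccc(C(=O)OC)cc1` gives 9470 nM

Compound 3 stands at the lower end of these results, alongside compound 1, and the two values lie within the scatter of each other. Compound 4 `CCOC(=O)c1c(C)nc(-c2cccc(C#N)c2)n1OCc1ccc(C#N)cc1` differs from compound 3 in one place cyano in place of methoxycarbonyl on an aromatic carbon with cyano in place of methoxycarbonyl on an aromatic carbon, para to a large group.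

For the measured compounds named here, two measured steps bear on this only indirectly. The first is an at least 1.7-fold higher number from compound 1 to compound 2 (0.23 log units; that floor lies within the scatter) and the second is an at least 3.1-fold lower number from compound 2 to compound 3 (0.50 log units; beyond the scatter) but neither exchanges the group on that aromatic carbon. The closest guide is compound 1, which lacks that aromatic ring altogether, yet its value (17600 nM) lies within the scatter of the value for compound 3 (9470 nM). A swap of one group on that ring is therefore not expected to move the number beyond the scatter in this assay and the expected step is small, with a 1.1-fold lower number from compound 3 to compound 4 (0.02 log units; within the scatter) as the estimate. For compound 4 the estimated value is 9000 nM with an expected range from 4000 nM to 20000 nM in this assay.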

Compound 4, half-maximal inhibitory concentration: 4240 nM
Compound 4: the middle estimate sits 2.1-fold (0.33 log units) above what was measured; measured number inside the range.
By their numbers in this assay, from the lowest: compound 4; then compounds 3 and 1 (each within the scatter of the next). At a limit, above all of these: compound 2.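

In this assay, for the compounds shown here, the earlier compounds left the outer ring unexplored, and the swap at this aromatic carbon, para to a large group, gives a 2.2-fold lower number from compound 3 to compound 4 (0.35 log units; beyond the scatter), so this place does respond to the group it carries, here with cyano, which has fewer heavy atoms than the methoxycarbonyl it replaces. The change also alters how the whole added group compares with the hydrogen on the oxygen of compound 1: compound 3 stood within the scatter of that compound, whereas the 4-cyanobenzyl group gives a 4.2-fold lower number from compound 1 to compound 4 (0.62 log units; beyond the scatter), the first substituent on that oxygen shown to lie beyond the scatter on the side of stronger inhibition. Replacing the carboxymethyl end of the chain with 4-cyanophenyl gives an at least 7.0-fold lower number from compound 2 to compound 4 (0.84 log units; beyond the scatter), a floor rather than a measured size, as its starting point is a limit of the assay: the limit of > 30000 nM in this assay, at which 1 of the 4 values shown sits.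

Going by these compounds alone, with only two groups compared at this aromatic carbon, no trend can be drawn, and it remains open how an amine, a carboxylic acid or a chlorine atom there would read in this assay. Going by these compounds, it is also open whether a longer chain linking the 4-cyanophenyl group to the oxygen would keep, lose or improve the number.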